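Methoxyphenyl placement on a benzimidazole-indole series

The source may hold more compounds than are shown below. What is called first, only, known or untested is meant among the compounds shown, and "the series" means these compounds.

Three members of the series have been run in a functional assay on HepG2 cells (Homo sapiens) for inhibition, read by MTT assay, with a stated time of 24 h; a higher number here means a weaker inhibitor of growth, a lower number a stronger inhibitor of growth. Compound 1 `COc1ccccc1C(=O)n1c(-c2cn(C)c3ccccc23)nc2ccccc21` gives 31800 nM. Compound 2 `COc1cccc(C(=O)n2c(-c3cn(C)c4ccccc34)nc3ccccc32)c1` gives 13600 nM. Compound 3 `COc1ccccc1C(=O)n1c(-c2cn(C)c3ccc(Br)cc23)nc2ccccc21` gives 34600 nM, the highest of the three numbers, though its distance from compound 1 lies within the scatter.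

Two single-point changes connect these. The first, (3-methoxyphenyl in place of 2-methoxyphenyl on a carbonyl carbon), gives a 2.3-fold lower number from compound 1 to compound 2 (0.37 log units; beyond the scatter). The second, (bromo in place of hydrogen on an aromatic carbon), gives a 1.1-fold higher number from compound 1 to compound 3 (0.04 log units; within the scatter), so compound 3 and compound 1 cannot be told apart in this assay.

Compound 4 `COc1cccc(C(=O)n2c(-c3cn(C)c4ccc(Br)cc34)nc3ccccc32)c1` has not been measured. It differs from compound 3 by 3-methoxyphenyl in place of 2-methoxyphenyl on a carbonyl carbon. This is the same change already made from compound 1 to compound 2, word for word at the same place, and it occurs twice among the four compounds. The two cores on which it is made differ by bromo in place of hydrogen on an aromatic carbon, a difference that left the number essentially unchanged.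

Going by the values given here, for compound 4 the expected step is a 2.3-fold lower number from compound 3 to compound 4 (0.36 log units; beyond the scatter), matching the earlier one because a 2.3-fold lower number from compound 1 to compound 2 (0.37 log units; beyond the scatter) is the only measured instance of this change and the core difference a 1.1-fold higher number from compound 1 to compound 3 (0.04 log units; within the scatter) was within the scatter. The rest is a single pair, so the range is kept wide. Compound 4 is estimated at 15000 nM, expected between 7000 nM and 32000 nM.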

Compound 4, concentration for 50% growth inhibition: 17800 nM
Beside the measured number, compound 4's estimate is 1.2-fold (0.07 log units) below it; measured number inside the range.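

In this assay, 3-methoxyphenyl in place of 2-methoxyphenyl on the carbonyl carbon gives a 1.9-fold lower number from compound 3 to compound 4 (0.29 log units; within the scatter), and this step agrees with the one on the core without bromo: the same change on two cores in this assay, a 2.3-fold lower number (0.37 log units; beyond the scatter) from compound 1 to compound 2 and a 1.9-fold lower number (0.29 log units; within the scatter) from compound 3 to compound 4, 1.2-fold (0.08 log units) apart, within the scatter of two such steps

Bromo in place of hydrogen, read on the 3-methoxyphenyl pair, gives a 1.3-fold higher number from compound 2 to compound 4 (0.12 log units; within the scatter), and this step agrees with the small step seen on the 2-methoxyphenyl pair: the same change on two cores in this assay, a 1.1-fold higher number (0.04 log units; within the scatter) from compound 1 to compound 3 and a 1.3-fold higher number (0.12 log units; within the scatter) from compound 2 to compound 4, 1.2-fold (0.08 log units) apart, within the scatter of two such steps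

The four compounds therefore show that, in this square, each change behaves alike on both cores, but the methoxy shift clears the scatter only on the core of compound 1, so a firm gain on the bromo core is not shown, and a single pair of cores gives no general rule for carrying the change across the series.

Still open, from the compounds shown here alone, is whether the step seen with the methoxy group holds when that group is replaced on the phenyl ring by a hydroxyl, a dimethylamino group or a carboxylic acid. Also open, going by these compounds, is whether chloro or a nitrile at the carbon bearing bromo would stay as close to hydrogen in this read-out as bromo does.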